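Adding a chloro group to compound 3

The source may hold more compounds than are shown below. What is called first, only, known or untested is meant among the compounds shown, and "the series" means these compounds.

Values in a functional assay on UACC-62 cells (Homo sapiens) for inhibition, with a stated time of 48 h (on this read-out lower numbers stand for stronger inhibition of growth and higher numbers for weaker inhibition of growth), so far
- Compound 1 `COc1ccccc1/C=C/C(=O)c1c(O)cc2occc2c1OC` gives 23700 nM
- Compound 2 `COc1c(C(=O)/C=C/c2ccc(Cl)cc2)c(O)c(Br)c2occc12` gives 3470 nM
- Compound 3 `C=CCc1c(O)c(C(=O)/C=C/c2ccccc2)c(OC)c2ccoc12` gives 2740 nM

Compound 3 sits with compound 2 at the low end of these numbers, the two within the usual scatter of each other, while compound 1 has a clearly higher number. Compound 4 `C=CCc1c(O)c(C(=O)/C=C/c2ccc(Cl)cc2)c(OC)c2ccoc12` alters compound 3 in one place (chloro in place of hydrogen on an aromatic carbon): chloro in place of hydrogen on an aromatic carbon, para to a large group, so phenyl becomes 4-chlorophenyl. Among the measured compounds shown here, no measured pair shows this change alone. Compound 2 (3470 nM) also carries 4-chlorophenyl but differs from compound 3 elsewhere as well. The expected step (a 1.2-fold lower number from compound 3 to compound 4 (0.08 log units; within the scatter)) is small and within the scatter, with no firm direction. The estimated value for compound 4 is 2300 nM (range 900 nM to 6000 nM).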

Compound 4, concentration for 50% growth inhibition: 2880 nM
Compound 4: middle estimate off by 1.3-fold (0.10 log units), on the low side, and the stated range covers the measured number.
By their numbers in this assay, from the lowest: compounds 3, 4 and 2 (each within the scatter of the next); then compound 1.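

In this assay, chloro in place of hydrogen on an aromatic carbon, para to a large group, gives a 1.1-fold higher number from compound 3 to compound 4 (0.02 log units; within the scatter), so phenyl and 4-chlorophenyl cannot be told apart on this read-out. Allyl in place of bromo on an aromatic carbon, at another place in the molecule, gives a 1.2-fold lower number from compound 2 to compound 4 (0.08 log units; within the scatter), so these two groups cannot be told apart either. Nothing available bears on the reason for these results. On these data alone, whether an amine or a carboxylic acid at the chloro position would shift the number beyond the scatter remains open.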